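Swapping Butyl for tert-Butyl: How Much Should Change?

The source may hold more compounds than are shown below. What is called first, only, known or untested is meant among the compounds shown, and "the series" means these compounds.

Of the compounds shown here, two have been measured so far in a functional assay on MCF7 cells (Homo sapiens) for inhibition (on this read-out lower numbers stand for stronger inhibition and higher numbers for weaker inhibition), and they sit close together. Compound 1 (`N#CC1CN1C(=O)Nc1ccc(Cl)c(Cl)c1`) gives 7200 nM there, and compound 2 (`CCCCNC(=O)N1CC1C#N`) gives 6700 nM there. These numbers lie within the usual scatter of repeated measurements, so compound 2 stands level with compound 1 and neither can be called the better inhibitor.

The next compound, compound 3 (`CC(C)(C)NC(=O)N1CC1C#N`), has the same atoms as compound 2, joined differently: tert-butyl in place of butyl on an amide-type nitrogen. Among the compounds with values here, no measured pair differs in only one place, so nothing shows this change directly. There is one indirect hint: compound 1 at 7200 nM and compound 2 at 6700 nM carry quite different groups on that nitrogen, yet stay within scatter of each other. A step beyond the scatter is therefore not expected in this assay here, though a slight drift towards weaker inhibition is possible. The estimate implies a 1.2-fold higher number from compound 2 to compound 3 (0.08 log units; within the scatter) as the expected change. For compound 3 the estimated half-maximal inhibitory concentration is 8000 nM with an expected range from 3500 nM to 20000 nM in this measurement.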

Compound 3, half-maximal inhibitory concentration: 190000 nM
Compound 3: middle estimate off by 24-fold (1.38 log units), on the low side; measured number outside the range, above it.
By their numbers in this assay, from the lowest: compounds 2 and 1 (each within the scatter of the next); then compound 3.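

Moving the same carbon atoms from butyl to tert-butyl on an amide-type nitrogen gives a 28-fold higher number from compound 2 to compound 3 (1.45 log units; beyond the scatter) in this assay, even though both groups have 4 heavy atoms, no ring and no net charge. This is the first pair shown that differs in only one place, and it makes clear that at this position the way the chain is joined can matter a great deal, not merely its atom count. The data give no explanation for the size of this step, and no measurement here bears on its cause.

This single step cannot show whether the weaker inhibition is specific to tert-butyl or would appear gradually with intermediate groups such as isobutyl or isopropyl, and it says nothing about a longer chain such as hexyl. Going by these compounds, whether the same change would have a similar effect with the dichlorophenyl group of compound 1 on this nitrogen, or on a core without the nitrile, also remains open.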